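This account rests on a few compounds, and the source may have more. Where it says the series, first, only, none or still open, it means among the compounds named here.

Measured in an ADME assay on HOS cells (Homo sapiens) for cytotoxicity, read by luminescence and ATP content, with a stated time of 48 h; on this read-out lower numbers stand for higher toxicity in this test and higher numbers for lower toxicity in this test:
- compound 1 `COc1ccc2c(O)c(C(=O)NCc3ccc(F)cc3F)c(=O)n(O)c2n1`: 12000 nM
- compound 2 `CN(C)CCCc1cnc2c(c1)c(N)c(C(=O)NCc1ccc(F)cc1F)c(=O)n2O`: 5000 nM

Compound 2 has the lower of these two numbers, and its gap to compound 1 lies beyond the usual scatter. Compound 3 `Nc1c(C(=O)NCc2ccc(F)cc2F)c(=O)n(O)c2ncc(CCC(=O)NCCO)cc12` has not yet been measured. It differs from compound 2 in one place: (2-hydroxyethyl)carbamoyl in place of (dimethylamino)methyl on a saturated chain carbon, two bonds along the chain from an aromatic carbon, with (2-hydroxyethyl)carbamoyl in place of (dimethylamino)methyl on a saturated chain carbon, two bonds along the chain from an aromatic carbon. Going by the values given here, no measured pair shows the effect of a single change, so the expectation is loose. Among the compounds with values here, a moderate move towards a higher number, meaning lower toxicity in this test, is expected, and compound 1 at 12000 nM gives the only rough guide to that range. The estimated step is a 3.0-fold higher number from compound 2 to compound 3 (0.48 log units; beyond the scatter). For compound 3 the expected value in this assay is 15000 nM, within an estimated range of 5000 nM to 50000 nM.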

Compound 3, half-maximal cytotoxic concentration: > 250000 nM
Compound 3: a limit, no number; the forecaster's own chance of this, stated with the estimate: 25%; at least 16-fold (1.22 log units) between middle value and limit.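

In this assay, putting (2-hydroxyethyl)carbamoyl in place of (dimethylamino)methyl on a saturated chain carbon, two bonds along the chain from an aromatic carbon, gives an at least 50-fold higher number from compound 2 to compound 3 (1.69 log units; beyond the scatter). Going by these compounds alone, this is the first single change read, and it shows that the group at this position can, on its own, shift the read-out far beyond the usual scatter. The entry for compound 3, > 250000 nM, is a limit of the assay and not a number, so the step has a floor but no upper end: the limit of > 250000 nM in this assay, at which 1 of the 3 values shown sits.

The compounds shown leave open which part of the change carries this step: the loss of the dimethylamino group, the new amide or the terminal hydroxyl. From the compounds shown here alone, whether a chain ending in a carboxylic acid or a morpholine would read like compound 2 or compound 3 also remains open.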